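This account rests on a few compounds, and the source may have more. Where it says the series, first, only, none or still open, it means among the compounds named here.

In a functional assay on SK-OV-3 cells (Homo sapiens) for cytotoxicity, read by sulforhodamine B assay (on this read-out higher numbers stand for weaker inhibition and lower numbers for stronger inhibition), compound 1 `O=C(/C=C/c1ccc(O)cc1)O[C@H]1[C@H](O[C@@H]2CCCC[C@H]2O)O[C@H](CO)[C@@H](O)[C@@H]1O` gives > 10000 nM, which is a limit of the assay and not a number. Compound 2 `O=C(/C=C\c1ccc(O)cc1)O[C@H]1[C@H](O[C@@H]2CCCC[C@H]2O)O[C@H](CO)[C@@H](O)[C@@H]1O` gives > 10000 nM in this assay, again a limit. Compound 3 `O=C(OC[C@H]1O[C@@H](O[C@@H]2CCCC[C@H]2O)[C@H](O)[C@@H](O)[C@@H]1O)c1ccc(O)cc1` gives > 10000 nM in this assay, also a limit.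

Compound 2 therefore stands at the limit of this assay, and so does every other measured compound; no numbered value exists for any of them. For the measured compounds named here, the one measured step between compounds that differ in a single place, a step that the two limits leave unreadable from compound 1 to compound 2, has no readable size because the limit of > 10000 nM in this assay, at which 3 of the 3 values shown sit, hides whatever change the double-bond geometry made, and the fact that compounds 1 and 2 differ only in the configuration as drawn is all that distinguishes the pair.

Compound 4 `O=C(/C=C/c1ccc(O)cc1)O[C@H]1[C@H](O[C@H]2CCCC[C@@H]2O)O[C@H](CO)[C@@H](O)[C@@H]1O` differs from compound 2 as follows: the two compounds have the same atoms and bonds and differ only in configuration as drawn: 3 of 8 stereo elements differ; a stereocentre at a saturated ring carbon is drawn R in compound 2 and S in compound 4; a stereocentre at a saturated ring carbon is drawn R in compound 2 and S in compound 4; a double bond is drawn Z in compound 2 and E in compound 4. Going by the values given here, the change in double-bond geometry is of the same kind as in the measured pair, which gave no readable step, and the two ring stereocentres have no measured counterpart at all. On this evidence no step beyond the scatter can be expected in this assay, and since all three measured values sit at the limit, the expectation is that compound 4 also reaches only the limit.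

Compound 4 is expected to give 15000 nM, with a range from 8000 nM to 50000 nM. The step this estimate means, a step that the limit leaves unreadable from compound 2 to compound 4, is expected to be negligible.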

Compound 4, half-maximal inhibitory concentration: > 10000 nM
Compound 4: a limit, no number; the forecaster's own chance of this, stated with the estimate: 85%; the middle value lies beyond the limit too.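

Neither step involving compound 4, from compound 1 or from compound 2, can be read, because both ends of each step sit at the same limit and give no number to compare: the limit of > 10000 nM in this assay, at which 4 of the 4 values shown sit. The compounds shown leave open whether the double-bond geometry or the two ring stereocentres change anything in this assay at all.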